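The source may report more compounds than this note shows. Statements on the series, on what has been measured and on what is new or still open speak of the compounds shown alone.

Compound 1 `COc1ccc(-c2cc(=O)c3ccc(OCCCCCN4CCC(CCO)CC4)cc3o2)cc1`, compound 2 `COc1ccc(-c2cc(=O)c3ccc(OCCCCCCN4CCC(C)CC4)cc3o2)cc1`, compound 3 `COc1ccc(-c2cc(=O)c3ccc(OCCCCCCN4CCC(CCO)CC4)cc3o2)cc1` and the not yet measured compound 4 `COc1ccc(-c2cc(=O)c3ccc(OCCCCCCCN4CCC(C)CC4)cc3o2)cc1` form a short series on one shared core. In a functional assay, read by spectrophotometry (on this read-out higher numbers stand for an effect only at larger amounts of compound and lower numbers for an effect already at smaller amounts), compound 1 gives 27.9 nM, compound 2 gives 32.6 nM and compound 3 gives 34.4 nM. The change from compound 1 to compound 2, ((4-methylpiperidin-1-yl)methyl in place of 4-(2-hydroxyethyl)piperidin-1-yl on a saturated chain carbon, five bonds along the chain from an oxygen on an aromatic ring), made a step of a 1.2-fold higher number from compound 1 to compound 2 (0.07 log units; within the scatter). The change from compound 3 to compound 4 is (4-methylpiperidin-1-yl)methyl in place of 4-(2-hydroxyethyl)piperidin-1-yl on a saturated chain carbon, six bonds along the chain from an oxygen on an aromatic ring. The two cores differ by (4-(2-hydroxyethyl)piperidin-1-yl)methyl in place of 4-(2-hydroxyethyl)piperidin-1-yl on a saturated chain carbon, five bonds along the chain from an oxygen on an aromatic ring, so the place reads six bonds along the chain from an oxygen on an aromatic ring instead of five bonds along the chain from an oxygen on an aromatic ring; it is the same kind of change, not the same. A step of a 1.1-fold higher number from compound 3 to compound 4 (0.04 log units; within the scatter) is expected in this assay because the earlier step of a 1.2-fold higher number from compound 1 to compound 2 (0.07 log units; within the scatter) stayed within the scatter. Compound 4 is accordingly estimated at 38 nM, with a range from 20 nM to 75 nM.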

Compound 4, half-maximal effective concentration: 42.6 nM
Estimate against measurement, compound 4: 1.1-fold (0.05 log units) below, and the stated range covers the measured number.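

In this assay, the change to (4-methylpiperidin-1-yl)methyl from 4-(2-hydroxyethyl)piperidin-1-yl carries from the core of compound 1 to the core of compound 3 as a small step, a 1.2-fold higher number from compound 3 to compound 4 (0.09 log units; within the scatter), and the two steps agree: the same change on two cores in this assay, a 1.2-fold higher number (0.07 log units; within the scatter) from compound 1 to compound 2 and a 1.2-fold higher number (0.09 log units; within the scatter) from compound 3 to compound 4, 1.1-fold (0.03 log units) apart, within the scatter of two such steps

The remaining steps, a 1.3-fold higher number from compound 2 to compound 4 (0.12 log units; within the scatter) and a 1.5-fold higher number from compound 1 to compound 4 (0.18 log units; within the scatter), also add nothing beyond the scatter. Going by these compounds alone, since neither paired step exceeds the scatter, the agreement shows only that this change stays small on these two cores; it does not show that a larger effect would carry over, or that other cores would behave alike.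

Still open, going by these compounds, is what a morpholine or a carboxylic acid in place of 4-methylpiperidin-1-yl would give in this assay. On these data alone, a much shorter chain also remains open.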